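Methyl to Trifluoromethyl in a Glutathione Transferase Inhibitor Series

The source may report more compounds than this note shows. Statements on the series, on what has been measured and on what is new or still open speak of the compounds shown alone.

Compound 1 `COc1ccccc1NC(=O)CCC(=O)OCCCCCCSc1ccc([N+](=O)[O-])c2nonc12`: 4050 nM
Compound 2 `Cc1ccc(NC(=O)CCC(=O)OCCCCCCSc2ccc([N+](=O)[O-])c3nonc23)cc1`: 6800 nM

Both compounds were tested in an assay on isolated protein for inhibition of glutathione S-transferase P (Homo sapiens), with a stated time of 10 min; on this read-out higher numbers stand for weaker inhibition and lower numbers for stronger inhibition. Compound 1 gives 4050 nM and compound 2 gives 6800 nM, so compound 2 has the higher of the two numbers, but the step of a 1.7-fold higher number from compound 1 to compound 2 (0.23 log units; within the scatter) means the two are indistinguishable. Compound 3 `O=C(CCC(=O)OCCCCCCSc1ccc([N+](=O)[O-])c2nonc12)Nc1ccc(C(F)(F)F)cc1` is not yet measured. It differs from compound 2 by trifluoromethyl in place of methyl on an aromatic carbon. Going by the values given here, the only measured step, from compound 1 to compound 2, swaps one substituted phenyl for another and was within the scatter; no measured pair shows a methyl-to-trifluoromethyl exchange, so there is no direct guide for the size of this step. With nothing in the data pointing either way, compound 3 is expected to land near compound 2, a step of a 1.1-fold lower number from compound 2 to compound 3 (0.05 log units; within the scatter), with an estimate of 6000 nM and a range from 2500 nM to 15000 nM.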

Compound 3, half-maximal inhibitory concentration: 5050 nM
Compound 3: middle estimate off by 1.2-fold (0.07 log units), on the high side; the measured number falls inside the stated range.
By their numbers in this assay, from the lowest: compounds 1, 3 and 2 (each within the scatter of the next).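

In this assay the exchange of methyl for trifluoromethyl on this aromatic carbon gives a 1.3-fold lower number from compound 2 to compound 3 (0.13 log units; within the scatter) so at this position, the larger group with its three fluorine atoms cannot be told apart from methyl. Placing the 4-(trifluoromethyl)phenyl group on the amide-type nitrogen in place of 2-methoxyphenyl gives a 1.2-fold higher number from compound 1 to compound 3 (0.10 log units; within the scatter) so all three compounds now lie within the scatter of one another. No measurement offered here accounts for this flat result.

The compounds shown leave open whether a group of a different kind at this ring position, such as an amine or a carboxylic acid, would move the number beyond the scatter. They also leave open whether a longer chain leading to the shared core would do so.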